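Removing the nitro group from a benzimidazole-based cytotoxic series

This account rests on a few compounds, and the source may have more. Where it says the series, first, only, none or still open, it means among the compounds named here.

Three compounds share a benzimidazole unit joined through a short linker to a second heteroaromatic ring. Compound 1 `NS(=O)(=O)c1nnc(NCc2nc3cc([N+](=O)[O-])ccc3[nH]2)s1` gives 176000 nM in a functional assay on HCT-116 cells (Homo sapiens) for cytotoxicity, read by MTT assay; on this read-out higher numbers stand for weaker inhibition and lower numbers for stronger inhibition. Compound 2 `O=[N+]([O-])c1ccc2[nH]c(CNc3nc4ccc(F)cc4s3)nc2c1` gives 253000 nM in this assay, and compound 3 `Fc1ccc2nc(NCc3nc4ccccc4[nH]3)sc2c1` gives 238000 nM. The three numbers lie within the scatter of one another, so no order among them can be claimed. How the core of compound 1 differs from the core of compound 2 is not broken down here.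

Compound 3 arises from compound 2 by one change, (hydrogen in place of nitro on an aromatic carbon), and this produced a 1.1-fold lower number from compound 2 to compound 3 (0.03 log units; within the scatter).

Compound 4 `NS(=O)(=O)c1nnc(NCc2nc3ccccc3[nH]2)s1` has not yet been measured. It arises from compound 1 by hydrogen in place of nitro on an aromatic carbon, which is the same change made from compound 2 to compound 3, at the same kind of place. Because the measured example of this change gave a 1.1-fold lower number from compound 2 to compound 3 (0.03 log units; within the scatter), the step is expected to be about a 1.1-fold lower number from compound 1 to compound 4 (0.04 log units; within the scatter) in this assay. Compound 4 is therefore estimated to give 160000 nM, most likely between 70000 nM and 350000 nM.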

Compound 4, half-maximal inhibitory concentration: 156000 nM
Compound 4: the middle estimate sits 1.0-fold (0.01 log units) above what was measured; the measured number falls inside the stated range.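

In this assay, putting hydrogen in place of the nitro group on the core of compound 1 gave a 1.1-fold lower number from compound 1 to compound 4 (0.05 log units; within the scatter), and this step can be set beside the same change on a second core: the same change on two cores in this assay, a 1.1-fold lower number (0.03 log units; within the scatter) from compound 2 to compound 3 and a 1.1-fold lower number (0.05 log units; within the scatter) from compound 1 to compound 4, 1.1-fold (0.03 log units) apart, within the scatter of two such steps

Neither step can be told apart from the ordinary spread of repeated measurements, so the two cores agree in showing no measurable effect of this swap. This agreement rests on just two pairs of compounds, so it does not show that the nitro group would be equally dispensable on any other core in the series, and a small real effect could lie hidden inside the scatter.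

What the compounds shown leave open is how this assay would respond if an amine, a carboxylic acid or a chlorine atom stood on that aromatic carbon instead. Also open, from the compounds shown here alone, is whether a longer chain between the two ring systems would give a different result.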